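Trading an Aromatic Cation for a Saturated One

The source may report more compounds than this note shows. Statements on the series, on what has been measured and on what is new or still open speak of the compounds shown alone.

Four compounds share one core and differ only in the charged group at the end of a chain that hangs from an oxygen on an aromatic ring. Compound 1 `CN(C)c1ccc2c(=O)c(C(=O)Nc3cc(F)cc(F)c3)cn(-c3ccc(OCCCCCCC[N+]4(C)CCCC4)cc3F)c2n1` and compound 2 `Cc1cc(OCCCCCCC[n+]2ccccc2)ccc1-n1cc(C(=O)Nc2cc(F)cc(F)c2)c(=O)c2ccc(N(C)C)nc21` are both recorded as inactive: in an assay on LX2 cells for inhibition of COL1A1 promoter (Homo sapiens), read by a luciferase reporter, with a stated time of 24 h, tested at 20 uM (on this read-out lower numbers stand for a weaker effect and higher numbers for a stronger effect at the one concentration tested), compound 1 gives "not active" (no number reported) and compound 2 gives "not active" (no number reported). Compound 3 `CN(C)c1ccc2c(=O)c(C(=O)Nc3cc(F)cc(F)c3)cn(-c3ccc(OCCCCCCC[n+]4ccccc4)cc3F)c2n1` is the only one of the three with a number, and in this assay compound 3 gives 15.4%, a modest effect at the single concentration.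

Compound 4 `CC[N+]1(CCCCCCCOc2ccc(-n3cc(C(=O)Nc4cc(F)cc(F)c4)c(=O)c4ccc(N(C)C)nc43)c(F)c2)CCCCC1` is the compound not yet measured. For the measured compounds named here, it differs from compound 3 in one place: a group of 8 heavy atoms (7 carbon, 1 nitrogen; one six-membered non-aromatic ring with 1 hetero atom) in place of a group of 6 heavy atoms (5 carbon, 1 nitrogen; one six-membered aromatic ring with 1 hetero atom), on a saturated chain carbon, seven bonds along the chain from an oxygen on an aromatic ring The charged group of compound 4 thus resembles in kind the one carried by compound 1, which showed no activity, more than the aromatic cation of compound 3.

Going by the values given here, no measured pair here shares a single change, so no step is available to lean on. The value of compound 1 being "not active" (no number reported) suggests that a saturated cationic ring does not help, and a loss of some size is expected, although the absolute effect of compound 3 is itself small. For compound 4 the expected step is a number 8.4 percentage points lower from compound 3 to compound 4 (within the scatter). Compound 4 is therefore estimated at 7%, within a range from 0% to 20%.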

Compound 4, a percentage reported as inhibition, at one concentration (the size of the read-out at that concentration, not a potency): "not active" (no number reported)
The entry for compound 4 holds no number; the estimate stays without a comparison.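

In this assay, for the compounds shown here, compound 4 gives "not active" (no number reported), so no step from compound 3 to compound 4 can be read. The compounds shown leave open how far the saturated ring of compound 4 separates it from the aromatic ring of compound 3 in size of effect. Nothing shown offers an explanation for this result.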